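Aryl Swap on the Triazole Nitrogen: From Compound 3 to 4

A few compounds are considered here, and "the series" means these few. Any claim that something is new, unique, unknown or untested is made for them only; others in the source may bear on it.

Compound 1, `N#CC1=C(N)Oc2c(c3nc4ccccc4nc3c3ccccc23)C12C(=O)N(Cc1cnnn1-c1ccccc1Br)c1ccccc12`, in a functional assay on HepG2 cells (Homo sapiens) for antiproliferative activity, read by MTT assay, with a stated time of 48 h; on this read-out higher numbers stand for weaker inhibition and lower numbers for stronger inhibition: > 50000 nM, a limit of the assay.
Compound 2, `CCOc1ccccc1-n1nncc1CN1C(=O)C2(C(C#N)=C(N)Oc3c2c2nc4ccccc4nc2c2ccccc32)c2ccccc21`, in this assay: > 50000 nM, a limit of the assay.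
Compound 3, `N#CC1=C(N)Oc2c(N)cc3nc4ccccc4nc3c2C12C(=O)N(Cc1cnnn1-c1ccc(Cl)cc1)c1ccccc12`, in this assay: > 50000 nM, a limit of the assay.

Compound 3 stands at the assay limit, and so do the two other measured compounds (the limit of > 50000 nM in this assay, at which 3 of the 3 values shown sit). Among the compounds with values here, the single step between measured compounds, a step that the two limits leave unreadable from compound 1 to compound 2, cannot be read because both ends are limits. Compound 4, `Cc1ccc(C)c(-n2nncc2CN2C(=O)C3(C(C#N)=C(N)Oc4c(N)cc5nc6ccccc6nc5c43)c3ccccc32)c1`, differs from compound 3 in one place: 2,5-dimethylphenyl in place of 4-chlorophenyl on an aromatic nitrogen. Within the data shown here, no measured step bears on this change, so no size or direction beyond the scatter is expected. Compound 4 is therefore estimated at 70000 nM, within 30000 nM to 200000 nM, most likely reported again only as a limit. The expected step is a step that the limit leaves unreadable from compound 3 to compound 4.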

Compound 4, half-maximal inhibitory concentration: > 50000 nM
Compound 4: no number, only a limit; the forecaster's own chance of this, stated with the estimate: 85%; the middle value does not contradict the limit.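

No step can be read between compound 3 and compound 4, as both results are limits and not numbers: the limit of > 50000 nM in this assay, at which 4 of the 4 values shown sit.
The compounds shown leave open whether 2,5-dimethylphenyl or 4-chlorophenyl makes any difference to the inhibition.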